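The compounds below may be only part of what the source reports. "The series", "measured", "known", "first", "only" and "open" are said of these compounds alone.

Working notes on the series

Two compounds in this set carry a measured value. Compound 1 `CC(C)(C)c1nc2c(C(=O)NCC3CCN(CC(O)CN4CCN(S(C)(=O)=O)CC4)CC3)cccc2[nH]1` gives in an assay on isolated protein for binding affinity to 5-hydroxytryptamine receptor 4 (Homo sapiens) (a lower number here means a stronger inhibitor, a higher number a weaker inhibitor), a value of 12.6 nM. Compound 2 `CC(C)c1nc2c(C(=O)NCC3CCN(CCN4CCN(S(C)(=O)=O)CC4)CC3)cccc2[nH]1` gives in this assay a value of 0.794 nM, the lowest of the two numbers shown, with compound 1 standing a long way above it and the gap between them beyond the usual scatter. Compound 1 and compound 2 differ in more than one place, so nothing is said here about which of those differences carries the gap.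

The step followed is that from compound 2 to compound 3 `COC(=O)N(C)CC(O)CN1CCC(CNC(=O)c2cccc3[nH]c(C(C)C)nc23)CC1`, not yet measured in this assay. The change is 1-hydroxy-2-((methoxycarbonyl)(methyl)amino)ethyl in place of (4-(methylsulfonyl)piperazin-1-yl)methyl on a saturated chain carbon bound to an amine nitrogen in a ring. For the measured compounds named here, no measured pair in the set isolates this change. On the two values shown, a step of moderate size toward a weaker result is expected from compound 2 to compound 3, a 7.6-fold higher number from compound 2 to compound 3 (0.88 log units; beyond the scatter), since compound 1, which also carries a hydroxyl on the chain, gives 12.6 nM. For compound 3 in this assay the value is estimated at 6 nM, with a range from 1.5 nM to 25 nM.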

Compound 3, inhibition constant: 3.98 nM
Beside the measured number, compound 3's estimate is 1.5-fold (0.18 log units) above it; measured number inside the range.
By their numbers in this assay, from the lowest: compound 2; then compound 3; then compound 1.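

In this assay, for the compounds shown here, putting 1-hydroxy-2-((methoxycarbonyl)(methyl)amino)ethyl in place of (4-(methylsulfonyl)piperazin-1-yl)methyl on a saturated chain carbon bound to an amine nitrogen in a ring gives a 5.0-fold higher number from compound 2 to compound 3 (0.70 log units; beyond the scatter), and this is the first step that isolates a change in one place. The step is modest: compound 3 still gives 3.98 nM without the six-membered non-aromatic ring and the sulfur of the leaving group, so at this position neither is required for a single-digit reading in this read-out, though compound 2 keeps the lower number. No supporting data bear on what lies behind the step.

The entering group differs from the leaving one in several features at once, so the shares of the hydroxyl, the methoxycarbonyl and the open chain in the step remain unresolved. The same chain without its hydroxyl, or an acetyl group or a plain dimethylamino end in place of the methoxycarbonyl(methyl)amino end, would help to separate these contributions.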